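Two fluorines on the aryl group: what compound 4 may give

A few compounds are considered here, and "the series" means these few. Any claim that something is new, unique, unknown or untested is made for them only; others in the source may bear on it.

Measured so far in a functional assay on MCF7 cells (Homo sapiens) for inhibition, read by MTT assay, with a stated time of 72 h; on this read-out higher numbers stand for weaker inhibition and lower numbers for stronger inhibition:
- compound 1 `CN(C(=O)NC(=O)c1ccccc1F)c1nc(C(F)(F)F)c(C(=O)N/N=C/c2cc(C(F)(F)F)cc(C(F)(F)F)c2)s1`: 6.16 ug/mL
- compound 2 `CN(C(=O)NC(=O)c1ccc(Cl)cc1Cl)c1nc(C(F)(F)F)c(C(=O)N/N=C/c2cc(C(F)(F)F)cc(C(F)(F)F)c2)s1`: > 100 ug/mL (a limit of the assay, not a number)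
- compound 3 `CN(C(=O)NC(=O)c1ccc(C(F)(F)F)cc1)c1nc(C(F)(F)F)c(C(=O)N/N=C/c2cc(C(F)(F)F)cc(C(F)(F)F)c2)s1`: 7.37 ug/mL

Among the numbers shown, compound 3 gives the higher of the two, and compound 1 sits within the scatter of it. For compound 2 the assay reports only a limit (the limit of > 100 ug/mL in this assay, at which 1 of the 3 values shown sits).

Compound 4 `CN(C(=O)NC(=O)c1c(F)cccc1F)c1nc(C(F)(F)F)c(C(=O)N/N=C/c2cc(C(F)(F)F)cc(C(F)(F)F)c2)s1` has not been measured. It differs from compound 3 in one place: 2,6-difluorophenyl in place of 4-(trifluoromethyl)phenyl on a carbonyl carbon.

Among the measured compounds shown here, two measured steps bear on this position. an at least 13-fold lower number from compound 2 to compound 3 (1.13 log units; beyond the scatter). a 1.2-fold higher number from compound 1 to compound 3 (0.08 log units; within the scatter). So a 2-fluorophenyl group and a 4-(trifluoromethyl)phenyl group give numbers within the scatter of each other, while a 2,4-dichlorophenyl group gives only a limit. Compound 4 carries fluorines, as compound 1 does, so no step beyond the scatter is expected from compound 3, namely a 1.1-fold lower number from compound 3 to compound 4 (0.02 log units; within the scatter).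

For compound 4 the expected value is 7 ug/mL, within the range 2.5 ug/mL to 30 ug/mL.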

Compound 4, half-maximal inhibitory concentration: 6.85 ug/mL
Compound 4: middle estimate off by 1.0-fold (0.01 log units), on the high side; the measured number falls inside the stated range.
By their numbers in this assay, from the lowest: compounds 1, 4 and 3 (each within the scatter of the next). At a limit, above all of these: compound 2.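

In this assay, the new compound shows that this carbonyl position tolerates a second fluorine, with a 1.1-fold higher number from compound 1 to compound 4 (0.05 log units; within the scatter), and that a 2,6-difluorophenyl group can stand in for a 4-(trifluoromethyl)phenyl group, with a 1.1-fold lower number from compound 3 to compound 4 (0.03 log units; within the scatter). Two halogens on the aromatic ring are therefore not enough on their own to produce the result of the 2,4-dichlorophenyl group, which stands apart with an at least 14-fold lower number from compound 2 to compound 4 (1.16 log units; beyond the scatter). Compound 2 gives a limit and not a number: the limit of > 100 ug/mL in this assay, at which 1 of the 4 values shown sits.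

Every aryl group shown here carries fluorine or chlorine, so it remains open whether the chlorines of compound 2 matter through their identity or through where they sit. As far as these compounds go, it is also open how a single chlorine, an amine or a carboxylic acid on this ring would compare with compound 1, compound 3 and compound 4.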